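Swapping a para ester for bromine on a carbamate

A few compounds are considered here, and "the series" means these few. Any claim that something is new, unique, unknown or untested is made for them only; others in the source may bear on it.

Compound 1 `C=C1C(=O)OC[C@H]1CCOC(=O)Nc1ccc(C(=O)OCCCC)cc1`: 430 nM
Compound 2 `C=C1C(=O)OC[C@@H]1CCOC(=O)Nc1cc(C(F)(F)F)cc(C(F)(F)F)c1`: 800 nM
Compound 3 `C=C1C(=O)OC[C@@H]1CCOC(=O)Nc1ccc(CC)cc1`: 1260 nM

These three compounds share one core and differ only in the aryl carbamate part. In a functional assay on RAW264.7 cells (Mus musculus) for inhibition, with a stated time of 30 min (a higher number here means a weaker inhibitor, a lower number a stronger inhibitor), compound 1 has the lowest of the three numbers; compound 2 lies within the scatter of it, so the two cannot be told apart, while compound 3 sits beyond it at a higher number. The unmeasured compound 4 `C=C1C(=O)OC[C@H]1CCOC(=O)Nc1ccc(Br)cc1` is obtained from compound 1 by a single change: bromo in place of butoxycarbonyl on an aromatic carbon. For the measured compounds named here, no measured pair isolates this change, so the expectation rests on the spread of the three values. The step of a 2.1-fold higher number from compound 1 to compound 4 (0.32 log units; beyond the scatter) is expected to be a slight weakening, possibly no larger than the scatter. The estimate for compound 4 is 900 nM, between 300 nM and 2700 nM.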

Compound 4, half-maximal inhibitory concentration: 350 nM
Beside the measured number, compound 4's estimate is 2.6-fold (0.41 log units) above it, within the range that was stated.
By their numbers in this assay, from the lowest: compounds 4, 1, 2 and 3 (each within the scatter of the next, the first and the last beyond it).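

Swapping butoxycarbonyl for bromo gives a 1.2-fold lower number from compound 1 to compound 4 (0.09 log units; within the scatter) in this assay, so the two compounds cannot be told apart. At this aromatic carbon, then, a single bromine atom serves as well in this assay as the seven heavy atoms of the ester, and the ester's two hydrogen-bond acceptors are not needed to keep the number at this level. Nothing measured here explains why the two values match. Going by these compounds, whether an amine, a carboxylic acid or a longer alkyl chain at this same carbon would also keep the number there remains open.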